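This account rests on a few compounds, and the source may have more. Where it says the series, first, only, none or still open, it means among the compounds named here.

Compound 1, `Cc1cc(=O)oc2cc(OCc3cn(-c4ccc(Cl)cc4)nn3)ccc12`, in an ADME assay on Huh-7 cells (Homo sapiens) for cytotoxicity, read by MTT assay, with a stated time of 72 h (a lower number here means that less compound is tolerated, a higher number that more compound is tolerated), gives > 100 ug/mL, which is a limit of the assay and not a number. Compound 2, `Cc1cc(=O)oc2cc(OCc3cn(-c4cccc(F)c4)nn3)ccc12`, in this assay gives > 100 ug/mL, again a limit of the assay.

Compound 2 therefore stands at the top limit of what was tested, and nothing more precise is known about it; both values shown sit at that limit (the limit of > 100 ug/mL in this assay, at which 2 of the 2 values shown sit). Going by the values given here, the only measured step, a step that the two limits leave unreadable from compound 1 to compound 2, is accordingly unreadable in size.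

Compound 3, `Cc1cc(=O)oc2cc(OCc3cn(Cc4ccccc4)nn3)ccc12`, differs from compound 2 by benzyl in place of 3-fluorophenyl on an aromatic nitrogen. Among the compounds with values here, the one measured step bears on this change only in that a swap of the group on the aromatic nitrogen left both values at the limit. No readable step is therefore expected in this assay, in either direction. Compound 3 is expected to give 150 ug/mL, with a range from 60 ug/mL to 400 ug/mL. That amounts to an expected step that the limit leaves unreadable from compound 2 to compound 3.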

Compound 3, half-maximal cytotoxic concentration: > 100 ug/mL
Compound 3 gave a limit, no number; the forecaster's own chance of this, stated with the estimate: 80%; the middle value lies beyond the limit too.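

No new step can be read among compound 1, compound 2 and compound 3, because all three values are limits of the assay and not numbers: the limit of > 100 ug/mL in this assay, at which 3 of the 3 values shown sit.

The compounds shown leave open where any of the three would reach its half-maximal cytotoxic concentration in this assay, and whether the group on the aromatic nitrogen changes it at all.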